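Methylsulfonyl for Methyl: Expected Solubility of Compound 4

The source may hold more compounds than are shown below. What is called first, only, known or untested is meant among the compounds shown, and "the series" means these compounds.

Of the compounds shown here, three sharing one core have been measured in a physicochemical assay for solubility, read by spectrophotometry, in phosphate buffer, with a stated time of 18 h, at pH 7.4; on this read-out lower numbers stand for lower solubility and higher numbers for higher solubility. Compound 1 `CCc1ccc(-c2nc3c(c(C)nn3-c3ccccc3)c(-c3ccccc3I)c2C#N)cc1` gives 8500 nM in this assay, and compound 2 `CCc1ccc(-c2nc3c(c(C)nn3-c3ccccc3)c(-c3ccccc3C(F)(F)F)c2C#N)cc1` gives 11000 nM. Between them there is only a 1.3-fold higher number from compound 1 to compound 2 (0.11 log units; within the scatter), a change of trifluoromethyl in place of iodo on an aromatic carbon. Going by the values given here, compound 3 `Cc1ccc(-c2nc3c(c(C)nn3-c3ccccc3)c(-c3ccccc3O)c2C#N)cc1` gives 26000 nM in this assay, the highest of the three numbers; its value lies beyond the scatter from both compound 2 and compound 1, though no single-point step links it to either of them.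

Compound 4 `Cc1nn(-c2ccccc2)c2nc(-c3ccc(S(C)(=O)=O)cc3)c(C#N)c(-c3ccccc3O)c12` differs from compound 3 by methylsulfonyl in place of methyl on an aromatic carbon. Among the compounds with values here, the only measured step, from compound 1 to compound 2, concerns a different ring and a different pair of groups, so no step yet measured bears directly on methylsulfonyl in place of methyl. The data therefore give no anchor of known size for this change, and the expectation must be wide.

The estimate for compound 4 in this assay is 45000 nM, with a range from 15000 nM to 130000 nM. This estimate means an expected step of a 1.7-fold higher number from compound 3 to compound 4 (0.24 log units; within the scatter), upward, and is held loosely. No comparable change has been measured in this series.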

Compound 4, solubility: 5000 nM
Beside the measured number, compound 4's estimate is 9.0-fold (0.95 log units) above it; the measured number lies below the stated range.
By their numbers in this assay, from the lowest: compounds 4, 1 and 2 (each within the scatter of the next, the first and the last beyond it); then compound 3.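

In this assay the 4-methylphenyl group of compound 3 proves open to change: with methylsulfonyl in place of methyl, the number falls by a 5.2-fold lower number from compound 3 to compound 4 (0.72 log units; beyond the scatter) and this is the first step shown here that lies beyond the scatter. Going by these compounds alone, the only earlier step, a 1.3-fold higher number from compound 1 to compound 2 (0.11 log units; within the scatter), stayed within the scatter and concerned a different ring and a different pair of groups, so it said nothing about this place, para to a large group. The new step shows that a change here can move the solubility read-out, and that this particular exchange moves it downward, but nothing available accounts for the size or direction of that fall.

On these data alone, whether the fall belongs to methylsulfonyl itself or would follow other replacements of methyl remains open, and an amine, a carboxylic acid or a longer chain on the same aromatic carbon would help to separate those readings. Also open, as far as these compounds go, is whether the exchange would give a step of like size with iodo or trifluoromethyl in place of the hydroxy group on the other ring.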